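Removing the hydroxy from the acid of compound 2

This account rests on a few compounds, and the source may have more. Where it says the series, first, only, none or still open, it means among the compounds named here.

Measured so far:
- compound 1, `CSCc1ccc(-c2cnc(C(=O)CCCCCCc3ccccc3)o2)nc1`: 11.1 nM
- compound 2, `O=C(O)CCCCc1cnc(C(=O)CCCCCCc2ccccc2)o1`: 23.8 nM

In an assay for inhibition of Fatty-acid amide hydrolase 1 (Rattus norvegicus), using a Dixon plot (on this read-out lower numbers stand for stronger inhibition and higher numbers for weaker inhibition), compound 2 gives the higher of the two numbers shown, and the one step recorded, a 2.1-fold higher number from compound 1 to compound 2 (0.33 log units; beyond the scatter), is modest and lies beyond the scatter. Compound 3, `O=CCCCCc1cnc(C(=O)CCCCCCc2ccccc2)o1`, differs from compound 2 by hydrogen in place of hydroxy on a carbonyl carbon, that is, carboxy to formyl at the end of the same chain. Going by the values given here, no measured step touches this change: the only recorded step swaps one whole side chain for another and says nothing about the end of the acid chain itself. Without guidance, the expectation is that compound 3 stays close to compound 2, with a 1.2-fold lower number from compound 2 to compound 3 (0.08 log units; within the scatter) as the assumed step, no larger than the scatter. The estimate for compound 3 in this assay is therefore 20 nM, with a range from 6 nM to 65 nM.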

Compound 3, inhibition constant: 14.6 nM
Compound 3: the middle estimate sits 1.4-fold (0.14 log units) above what was measured; low and high end bracket the measured number.
By their numbers in this assay, from the lowest: compounds 1, 3 and 2 (each within the scatter of the next, the first and the last beyond it).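

In this assay the change from carboxy to formyl at the end of the chain gives a 1.6-fold lower number from compound 2 to compound 3 (0.21 log units; within the scatter) and so shows that the hydroxy of the acid can be replaced by hydrogen with no difference beyond the usual scatter. The step of a 1.3-fold higher number from compound 1 to compound 3 (0.12 log units; within the scatter) is also within the scatter, so a ring-free chain ending in formyl at this aromatic carbon matches the ring-bearing group of compound 1, which the acid chain of compound 2 did not quite do. Nothing measured here explains why these numbers fall as they do.

With one pair at this chain end, the result cannot say which feature of the end group matters, or whether it matters at all. An alcohol, an amide or a methyl ester at the chain end, or a longer chain, could still behave differently.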